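The source may hold more compounds than are shown below. What is called first, only, known or untested is meant among the compounds shown, and "the series" means these compounds.

Compound 2 `CCOC(=O)c1cc(=O)c2cc(CSC(=S)N(C)c3ccccc3)ccc2o1` stands second highest among the three numbers measured in a functional assay on MDA-MB-435S cells (Homo sapiens) for antiproliferative activity, read by MTT assay, with a stated time of 72 h; a lower number here means a stronger inhibitor, a higher number a weaker inhibitor: compound 2 gives 13500 nM. Compound 1 `O=c1c(SC(=S)N2CCCCC2)coc2ccccc12`, which also bears piperidin-1-yl on a thiocarbonyl carbon, gives 17400 nM, a number within the scatter of compound 2. Compound 3 `Cc1ccc2c(=O)c(CSC(=S)N3CCOCC3)coc2c1` gives 5500 nM, a lower number beyond the scatter. Compound 4 `CCOC(=O)c1cc(=O)c2cc(CSC(=S)N3CCCCC3)ccc2o1` has not been measured; it differs from compound 2 in one place: piperidin-1-yl in place of methyl(phenyl)amino on a thiocarbonyl carbon. Among the measured compounds shown here, no measured pair isolates this change, so its direction is open. Because compound 1 gives 17400 nM with the same entering group, no step beyond the scatter is expected. Compound 4 is estimated at 12000 nM, within 5000 nM to 30000 nM. The expected step of a 1.1-fold lower number from compound 2 to compound 4 (0.05 log units; within the scatter) is small and lies within the scatter.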

Compound 4, half-maximal inhibitory concentration: 2900 nM
Beside the measured number, compound 4's estimate is 4.1-fold (0.62 log units) above it; the whole stated range lies above it.
By their numbers in this assay, from the lowest: compounds 4 and 3 (each within the scatter of the next); then compounds 2 and 1 (each within the scatter of the next).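

In this assay, among the compounds shown here, piperidin-1-yl in place of methyl(phenyl)amino on a thiocarbonyl carbon gives a 4.7-fold lower number from compound 2 to compound 4 (0.67 log units; beyond the scatter), the first measured pair to isolate this change. It shows that the number at this position depends on the group carried there, and that this change lowers it beyond the scatter, though nothing measured here explains why.

A single pair leaves open whether the step follows from gaining the non-aromatic ring or losing the phenyl ring. It also leaves open how pyrrolidin-1-yl or diethylamino would read on the same thiocarbonyl carbon.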